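This account rests on a few compounds, and the source may have more. Where it says the series, first, only, none or still open, it means among the compounds named here.

Of the compounds shown here, two have been measured in an assay on HEK293 cells for positive allosteric modulation of metabotropic glutamate receptor 3 (Rattus norvegicus), read by thallium flux, with a stated time of 2.5 min; on this read-out lower numbers stand for smaller maximal responses and higher numbers for larger maximal responses. Compound 1 `Cc1c(OCCCCOc2cccc(C(=O)O)c2)ccc(C(=O)CC2CCCC2)c1O` gives 92.9%, while compound 2 `Cc1c(OCCCCOc2cccc(C(=O)O)c2)ccc(C(=O)CC(C)C)c1C` gives 18.3%. These two differ in more than one place, so their values can only be set side by side: compound 2 holds the lowest of the two numbers, and the nearest value, that of compound 1, lies well beyond the scatter above it.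

Compound 3 `Cc1c(OCCCCOc2cccc(C(=O)O)c2)ccc(C(=O)CC2CCCC2)c1C` has not yet been measured. It differs from compound 2 in one place:

cyclopentyl in place of isopropyl on a saturated chain carbon bound to a carbonyl carbon

Among the compounds with values here, no measured pair in this set shows this change on its own, so its effect is not known from these data. Since compound 1 carries the cyclopentyl group and gives 92.9%, while compound 2 gives 18.3%, an upward step in this assay of moderate size, beyond the scatter, is expected for compound 3, although the step is uncertain. The expected step is a number 21.7 percentage points higher from compound 2 to compound 3 (beyond the scatter). Compound 3 is estimated to give 40%, with a range from 15% to 75%.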

Compound 3, largest response reached (reported as percent of maximum), in percent of the reference or control that the assay uses: 16.5%
Beside the measured number, compound 3's estimate is 23.5 percentage points above it; low and high end bracket the measured number.
By their numbers in this assay, from the lowest: compounds 3 and 2 (each within the scatter of the next); then compound 1.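

In this assay, cyclopentyl in place of isopropyl on a saturated chain carbon bound to a carbonyl carbon gives a number 1.8 percentage points lower from compound 2 to compound 3 (within the scatter), so with methyl on the aromatic carbon these two groups cannot be told apart on this read-out. The wide gap between the first two compounds therefore does not follow the cyclopentyl group, since methyl in place of hydroxy on an aromatic carbon gives a number 76.4 percentage points lower from compound 1 to compound 3 (beyond the scatter) and so accounts for the large difference on its own, a step the earlier pair, differing in more than one place, could not isolate. Nothing available here bears on the reason for either step.

The compounds shown leave open whether hydroxy on that aromatic carbon would give a similarly large response with isopropyl on the chain, and so whether the effect of hydroxy depends on the cyclopentyl group. They also leave open how a methoxy group or an amine on that aromatic carbon would compare with hydroxy, and whether a longer chain at the carbonyl would matter once hydroxy is present.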